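The compounds below may be only part of what the source reports. "The series", "measured", "known", "first", "only" and "open" are said of these compounds alone.

Measured so far:
- compound 1 `Cc1nc(SCC(=O)Nc2nc(-c3ccc(Cl)cc3)cs2)n(Nc2ccccc2)c1C`: 54200 nM
- compound 2 `Cc1ccc(Nn2c(SCC(=O)Nc3nc(-c4ccccc4)cs3)nc(C)c2C)cc1`: > 100000 nM

Within the data shown here, in a functional assay on OVCAR-5 cells (Homo sapiens) for antiproliferative activity, read by sulforhodamine B assay, with a stated time of 48 h (a higher number here means that more compound is tolerated, a lower number that less compound is tolerated), compound 1 gives 54200 nM, the only plain number. Compound 2 gives > 100000 nM, which is a limit of the assay, and the limit of > 100000 nM in this assay, at which 1 of the 2 values shown sits, marks where that limit sits. Compound 3 `COc1ccc(Nn2c(SCC(=O)Nc3nc(-c4ccc(Cl)cc4)cs3)nc(C)c2C)cc1` differs from compound 1 by methoxy in place of hydrogen on an aromatic carbon. Among the measured compounds shown here, no measured pair covers this change, so the step from compound 1 to compound 3 is expected to be small, a 1.3-fold higher number from compound 1 to compound 3 (0.11 log units; within the scatter), hardly beyond the scatter. Compound 3 is estimated at 70000 nM, within 25000 nM to 200000 nM, with a real chance of only a limit.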

Compound 3, concentration lethal to 50% of the cells: > 100000 nM
Compound 3 gave a limit, no number; the forecaster's own chance of this, stated with the estimate: 40%; at least 1.4-fold (0.15 log units) between middle value and limit.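

In this assay, going from anilino to (4-methoxyphenyl)amino gives an at least 1.8-fold higher number from compound 1 to compound 3 (0.26 log units; that floor lies within the scatter), the first step read at this position, and only its floor is known. Compound 3 gives a limit and no number, so the step may be larger than that floor, and the series now holds more limits than plain numbers: the limit of > 100000 nM in this assay, at which 2 of the 3 values shown sit.

From the compounds shown here alone, whether the true step exceeds the scatter stays open. So does whether an amine or a carboxylic acid on this aromatic carbon would give a value inside the measurable range.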